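Swapping Chloro for Fluoro on a Smaller Core

A few compounds are considered here, and "the series" means these few. Any claim that something is new, unique, unknown or untested is made for them only; others in the source may bear on it.

Three compounds have so far been measured in a functional assay on cells for positive allosteric modulation of metabotropic glutamate receptor 2 (Homo sapiens), read by fluorescence and calcium flux, with a stated time of 30 min; a higher number here means that more compound is needed for the effect, a lower number that less compound is needed:

compound 1, `Fc1cc(C(F)(F)F)ccc1-c1ccc(Cn2nnc3ccccc32)cc1`: 29 nM
compound 2, `FC(F)(F)c1ccc(-c2ccc(Cn3nnc4ccccc43)cc2)c(Cl)c1`: 37 nM
compound 3, `Clc1cccc2c1nnn2CC1CC1`: 90 nM

Compound 2 and compound 1 differ in one place, (fluoro in place of chloro on an aromatic carbon). This gave a 1.3-fold lower number from compound 2 to compound 1 (0.11 log units; within the scatter). Compound 3 carries a different core; the difference between its core and that of compound 2 is not broken down here. Compound 3 has the highest number of the three, and its gap to both compound 2 and compound 1 lies beyond the scatter.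

Compound 4, `Fc1cccc2c1nnn2CC1CC1`, has not yet been measured. It differs from compound 3 by fluoro in place of chloro on an aromatic carbon. This is the same kind of change as from compound 2 to compound 1, but the surroundings differ: in compound 3 the carbon belongs to a fused system of two rings, ortho to a fused ring and meta to a fused ring, whereas in compound 2 it is ortho to a large group and meta to a trifluoromethyl group. Among the compounds with values here, since the only measured example of this change, a 1.3-fold lower number from compound 2 to compound 1 (0.11 log units; within the scatter), stayed within the scatter, a similarly small step is expected here, a 1.1-fold lower number from compound 3 to compound 4 (0.05 log units; within the scatter). Compound 4 is therefore estimated at 80 nM, expected between 35 nM and 200 nM.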

Compound 4, half-maximal effective concentration: 1070 nM
Beside the measured number, compound 4's estimate is 13-fold (1.13 log units) below it; measured number outside the range, above it.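

In this assay, fluoro in place of chloro on an aromatic carbon of the smaller core gave a 12-fold higher number from compound 3 to compound 4 (1.08 log units; beyond the scatter), so on this core far more compound is needed for the effect once chloro has left. The same swap therefore does not bring a fixed step from one core to another in this series, and a step read on one core cannot simply be copied to the other: the same change on two cores in this assay, a 1.3-fold lower number (0.11 log units; within the scatter) from compound 2 to compound 1 and a 12-fold higher number (1.08 log units; beyond the scatter) from compound 3 to compound 4, 15-fold (1.18 log units) apart, beyond the scatter of two such steps

This does not show why the two cores answer so differently, as the cores differ in many places at once, and two cores are too few to tell which of those places matters or to predict the step on a third core.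

The compounds shown leave open how other groups on that same carbon of compound 3 would behave, such as bromo, methyl or methoxy. They also leave open whether the swap on a core carrying an amine or a longer chain would give a small step or a large one.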